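A few compounds are considered here, and "the series" means these few. Any claim that something is new, unique, unknown or untested is made for them only; others in the source may bear on it.

Measured so far:
compound 1 `Cc1cc(/N=c2\[nH]c(=O)n(C[C@H](C)C(=O)O)c(=O)n2Cc2ccc(Cl)cc2)ccc1OC(C)C` — 102%
compound 2 `C[C@@H](Cn1c(=O)[nH]/c(=N\c2ccc(Oc3cccc(F)n3)cc2)n(Cc2ccc(Cl)cc2)c1=O)C(=O)O` — 60%
compound 3 `CC(C)Oc1ccc(Nc2nc(=O)n(CCCO)c(=O)n2Cc2ccc(Cl)cc2)cc1Cl` — 36.2%

In an ADME assay on the whole organism (Rattus norvegicus) for pharmacokinetics, using cassette dosing, at a dose of 1 mg/kg by the oral route (a higher number here means that a larger share of the oral dose reaches the circulation, a lower number that a smaller share of the oral dose reaches the circulation), compound 1 gives 102%, the highest of the three numbers. Compound 2 stands nearest with 60%, a gap beyond the scatter; compound 3 stands furthest with 36.2%, again beyond the scatter. No two of these compounds differ in one place only, so no single measured step is in hand. Compound 4 `C[C@@H](Cn1c(=O)[nH]/c(=N\c2ccc(OC3CCC3)cc2)n(Cc2ccc(Cl)cc2)c1=O)C(=O)O` is next to be run in this assay. Against compound 1 the change is: 4-(cyclobutyloxy)phenyl in place of 4-isopropoxy-3-methylphenyl on a double-bonded nitrogen. Compound 1 sits at the top of the numbers shown, and the change is expected to bring a moderate fall rather than none. Compound 4 is expected to give 70%, within 45% to 95%. That estimate means a step of a number 32 percentage points lower from compound 1 to compound 4 (beyond the scatter), expected to lie beyond the scatter.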

Compound 4, oral bioavailability: 54.3%
The estimate for compound 4 lay 15.7 percentage points above the measured number; low and high end bracket the measured number.
By their numbers in this assay, from the lowest: compound 3; then compounds 4 and 2 (each within the scatter of the next); then compound 1.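

In this assay, 4-(cyclobutyloxy)phenyl in place of 4-isopropoxy-3-methylphenyl on a double-bonded nitrogen gives a number 47.7 percentage points lower from compound 1 to compound 4 (beyond the scatter), the first single-place change showing that this position can move the read-out substantially. On an oxygen on an aromatic ring, cyclobutyl in place of 6-fluoropyridin-2-yl gives a number 5.7 percentage points lower from compound 2 to compound 4 (within the scatter), so this pair is not separated here. No measurement at hand accounts for either step.

Going by these compounds, whether the loss of the methyl or the change from isopropyl to cyclobutyl drives the first step remains open. On these data alone, how a cyclopentyl or an ethyl group on that oxygen would read also remains open.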